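The compounds below may be only part of what the source reports. "The series", "measured", "known", "first", "only" and "open" are said of these compounds alone.

Compound 1, `COc1cc(-c2nnc3n2NC(c2ccco2)C(C(=O)c2ccccc2C)S3)cc(OC)c1OC`, gives 80000 nM in a functional assay on A549 cells (Homo sapiens) for cytotoxicity, read by MTT assay, with a stated time of 48 h; a higher number here means a weaker inhibitor, a lower number a stronger inhibitor.
Compound 2, `COc1cc(-c2nnc3n2NC(c2ccco2)C(C(=O)c2ccccc2F)S3)cc(OC)c1OC`, gives 78700 nM in this assay.
Compound 3, `COc1cc(-c2nnc3n2NC(c2ccco2)C(C(=O)c2ccc(Cl)cc2)S3)cc(OC)c1OC`, gives 51400 nM in this assay.

Compound 1 has the highest of the three numbers, yet its distance to compound 2 is a 1.0-fold lower number from compound 1 to compound 2 (0.01 log units; within the scatter) and to compound 3 is a 1.6-fold lower number from compound 1 to compound 3 (0.19 log units; within the scatter), so the three compounds cannot be told apart on these data. Compound 4, `COc1cc(-c2nnc3n2NC(c2ccco2)C(C(=O)c2ccco2)S3)cc(OC)c1OC`, differs from compound 1 in one place: furan-2-yl in place of 2-methylphenyl on a carbonyl carbon. For the measured compounds named here, two measured steps touch the same carbonyl carbon: a 1.6-fold lower number from compound 1 to compound 3 (0.19 log units; within the scatter) and a 1.5-fold lower number from compound 2 to compound 3 (0.19 log units; within the scatter). Going by the values given here, both remain inside the scatter, and no measured step brings a furan-2-yl into this place, so nothing here points to a change beyond the scatter for compound 4. The expected step for compound 4 is therefore a 1.1-fold lower number from compound 1 to compound 4 (0.06 log units; within the scatter), which is small. Compound 4 is estimated to give 70000 nM in this assay, with a range from 30000 nM to 160000 nM.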

Compound 4, half-maximal inhibitory concentration: 68700 nM
The estimate for compound 4 lay 1.0-fold (0.01 log units) above the measured number; low and high end bracket the measured number.
By their numbers in this assay, from the lowest: compounds 3, 4, 2 and 1 (each within the scatter of the next).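

For the compounds shown here, compound 4 puts a five-membered aromatic ring with a hetero atom on this carbonyl carbon, where the earlier compounds all carry a six-membered aromatic ring of carbon only. In this assay the steps are a 1.2-fold lower number from compound 1 to compound 4 (0.07 log units; within the scatter) and a 1.1-fold lower number from compound 2 to compound 4 (0.06 log units; within the scatter) and a 1.3-fold higher number from compound 3 to compound 4 (0.13 log units; within the scatter) and so this change of ring size, and the added hydrogen-bond acceptor, leaves compound 4 indistinguishable from the other three compounds. Nothing available here explains why these four groups read alike.

Every group shown at this position is an aromatic ring, so what an amine, a carboxylic acid or a longer chain would do on this carbonyl carbon remains open. As far as these compounds go, it also remains open whether any change at this position can move the number beyond the scatter.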